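A few compounds are considered here, and "the series" means these few. Any claim that something is new, unique, unknown or untested is made for them only; others in the source may bear on it.

Of the compounds shown here, three built on one shared core have been tested in a functional assay on Caco-2 cells (Homo sapiens) for cytotoxicity, read by MTT assay, with a stated time of 4 h (a higher number here means a weaker inhibitor, a lower number a stronger inhibitor), and only one of them gave a number. Compound 1 `COC(=O)C1=CO[C@@H](O[C@@H]2O[C@H](CO)[C@@H](OC(C)=O)[C@H](OC(C)=O)[C@H]2OC(C)=O)[C@@H]2[C@@H](C)[C@@H](OC(C)=O)C[C@H]12` is recorded as "not active" (no number reported) and has no figure to compare. Compound 2 `CCCCCCCCCCCC(=O)OC[C@H]1O[C@@H](O[C@@H]2OC=C(C(=O)OC)[C@H]3C[C@H](OC(C)=O)[C@H](C)[C@@H]23)[C@H](OC(C)=O)[C@@H](OC(C)=O)[C@@H]1OC(C)=O` gives 0.42 ug/mL and so stands alone, with no numeric neighbour to be ranked against. Compared with compound 2, compound 3 `CCCCCCCCCCCCCC(=O)OC[C@H]1O[C@@H](O[C@@H]2OC=C(C(=O)OC)[C@H]3C[C@H](OC(C)=O)[C@H](C)[C@@H]23)[C@H](OC(C)=O)[C@@H](OC(C)=O)[C@@H]1OC(C)=O` has a longer chain in the same place and is recorded as "not active" (no number reported) with no figure either.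

Going by the values given here, the next compound, compound 4 `COC(=O)C1=CO[C@@H](O[C@@H]2O[C@H](COC(=O)c3cccc([N+](=O)[O-])c3)[C@@H](OC(C)=O)[C@H](OC(C)=O)[C@H]2OC(C)=O)[C@@H]2[C@@H](C)[C@@H](OC(C)=O)C[C@H]12`, keeps the rest of compound 2 and carries 3-nitrophenyl in place of undecyl on a carbonyl carbon as its single change. Among the compounds with values here, no step between two measured numbers exists here, so the size of this change can only be judged. That judgement rests on compound 2 at 0.42 ug/mL being the lone figure in a set where compound 1 at "not active" (no number reported) and compound 3 at "not active" (no number reported) gave none. A move towards a higher number, meaning a weaker inhibitor, is expected, and compound 4 may well give no number at all. The expected change is a 4.8-fold higher number from compound 2 to compound 4 (0.68 log units; beyond the scatter) and would lie beyond the usual scatter. If a number appears, the estimate for compound 4 is 2 ug/mL with an expected range from 0.3 ug/mL to 15 ug/mL in repeated measurements.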

Compound 4, half-maximal inhibitory concentration: 1 ug/mL
Compound 4: middle estimate off by 2.0-fold (0.30 log units), on the high side, within the range that was stated.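

In this assay, replacing undecyl with 3-nitrophenyl on a carbonyl carbon gives a 2.4-fold higher number from compound 2 to compound 4 (0.38 log units; beyond the scatter), the first measured size for a change at this position, and it is a modest one. A measurable figure here therefore does not require a straight alkyl chain, since compound 4, which carries an aromatic ring with a nitro group, also gives a number, while the steps to compound 1 and compound 3 cannot be read, as neither has a figure. Nothing measured in this set explains the shift to a higher number.

The compounds shown leave open whether the nitro group matters, as a plain phenyl or a 3-aminophenyl on the same carbonyl carbon would be needed to separate its contribution from that of the ring. They also leave open how sharply the outcome depends on chain length, since a shorter chain such as hexyl would show whether numbers persist on that side of undecyl, given that the longer chain of compound 3 gave none.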